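Cytotoxicity notes on the furan-to-dichlorophenyl step

The compounds below may be only part of what the source reports. "The series", "measured", "known", "first", "only" and "open" are said of these compounds alone.

Measured so far in an ADME assay on HepG2 cells (Homo sapiens) for cytotoxicity, read by CellTiter-Glo and resazurin assay, with a stated time of 72 h; a higher number here means that more compound is needed for the effect, a lower number that less compound is needed:
Compound 1 `CC(C)N(Cc1cccc(OCCCCCC(=O)O)c1)C(=O)c1ccc(-c2ccoc2)cc1` gives > 26000 nM, which is a limit of the assay rather than a number.
Compound 2 `CCOC(=O)CCCCCOc1cccc(CN(C(=O)c2ccc(-c3ccoc3)cc2)C(C)C)c1` gives > 26000 nM, again a limit of the assay.
Compound 3 `CCOC(=O)CCCCCOc1cccc(CN(C(=O)c2ccc(-c3cc(C(F)(F)F)cc(C(F)(F)F)c3)cc2)C(C)C)c1` gives > 26000 nM, also a limit of the assay.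

Compound 2 therefore stands only at a limit in this assay, and the other two values shown are limits as well; all three sit at the limit of > 26000 nM in this assay, at which 3 of the 3 values shown sit. Within the data shown here, the one step between measured compounds that differ in a single place, a step that the two limits leave unreadable from compound 1 to compound 2, ethyl in place of hydrogen on an oxygen next to a carbonyl group, is left unreadable by the two limits.

The step now followed leads from compound 2 to compound 4 `CCOC(=O)CCCCCOc1cccc(CN(C(=O)c2ccc(-c3ccc(Cl)c(Cl)c3)cc2)C(C)C)c1`. The change is 3,4-dichlorophenyl in place of furan-3-yl on an aromatic carbon. No measured step bears directly on this exchange: compound 3 carries a different six-membered ring in the same place, but no step to it is shown, and its value is a limit like that of compound 2. What the data give is three limits and no readable step, so no direction can be drawn from them.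

Compound 4 is accordingly expected to give about 30000 nM, within 10000 nM to 100000 nM, most likely reported again as a limit. The expected step that the limit leaves unreadable from compound 2 to compound 4 is thus none beyond the scatter, with the understanding that this expectation rests on limits only.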

Compound 4, half-maximal effective concentration: > 26000 nM
Compound 4: only a limit was reported; the forecaster's own chance of this, stated with the estimate: 75%; the middle value is on the limit's open side.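

Compound 4 stands at a limit of the assay in this assay with > 26000 nM as its entry, and this is not a number. No step can be read from compound 2 to compound 4, and the series offers no comparison: the limit of > 26000 nM in this assay, at which 4 of the 4 values shown sit.

The compounds shown leave open where any of them reaches the half-maximal effect in this assay and whether exchanging furan-3-yl for 3,4-dichlorophenyl shifts that concentration.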